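The compounds below may be only part of what the source reports. "The series", "measured", "known", "first", "only" and "open" are said of these compounds alone.

In a functional assay, with a stated time of 60 min, tested at 0.5 mM (a lower number here means a weaker effect, a higher number a stronger effect of the compound at the concentration tested), the compounds measured so far gave these numbers:

compound 1 `COC(=O)c1c(O)c2ccccc2n(-c2ccccc2)c1=O`: 19.3%
compound 2 `NCCNC(=O)c1c(O)c2ccccc2n(-c2ccccc2)c1=O`: 7.9%
compound 3 `Cn1c(=O)c(C(=O)NCCCCCCN)c(O)c2ccccc21`: 21.9%

Compound 3 holds the highest of the three numbers, but its gap to compound 1 lies within the usual scatter; only compound 2 sits beyond it. Compound 4 `NCCCCCCNC(=O)c1c(O)c2ccccc2n(-c2ccccc2)c1=O` differs from compound 3 by phenyl in place of methyl on an aromatic nitrogen. For the measured compounds named here, the one measured step, a number 11.4 percentage points lower from compound 1 to compound 2 (beyond the scatter), alters a different part of the shared core and so does not bear directly on this change; no measured pair differs only at the aromatic nitrogen. Compounds 1 and 2, which already carry the phenyl there, both give numbers in the same low region as compound 3. For compound 4 the step of a number 3.9 percentage points lower from compound 3 to compound 4 (within the scatter) is therefore expected to stay within the scatter, in neither direction. Compound 4 is estimated at 18%, with a range of 7% to 30%.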

Compound 4, a percentage reported as activity, at one concentration (the size of the read-out at that concentration, not a potency): 28.1%
Estimate against measurement, compound 4: 10.1 percentage points below; low and high end bracket the measured number.
By their numbers in this assay, from the lowest: compound 2; then compounds 1, 3 and 4 (each within the scatter of the next).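

Placing phenyl instead of methyl on the aromatic nitrogen leaves this assay within the scatter (a number 6.2 percentage points higher from compound 3 to compound 4 (within the scatter)), so with the (6-aminohexyl)amino group in place, this read-out does not separate the two groups. With phenyl on that nitrogen, (6-aminohexyl)amino in place of methoxy also stays within the scatter (a number 8.8 percentage points higher from compound 1 to compound 4 (within the scatter)), whereas 4-aminobutyl in place of amino on the shorter chain goes beyond it (a number 20.2 percentage points higher from compound 2 to compound 4 (beyond the scatter)). No evidence here explains these steps. On these data alone, whether benzyl on the nitrogen, or a carboxylic acid in place of the chain-end amine, would fit this picture remains open.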